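A naphthyl replacement tried on an inactive thiazolyl pyrazoline

The source may hold more compounds than are shown below. What is called first, only, known or untested is meant among the compounds shown, and "the series" means these compounds.

Compound 1 `O=[N+]([O-])c1ccc(-c2csc(N3N=C(c4ccc(N5CCCCC5)cc4)CC3c3ccc(Cl)cc3)n2)cc1` is measured in a functional assay on MCF7 cells (Homo sapiens) for antiproliferative activity, read by MTT assay, with a stated time of 72 h; a higher number here means a weaker inhibitor, a lower number a stronger inhibitor. In this assay compound 1 reaches only the limit > 100000 nM, not a number. Compound 2 `CS(=O)(=O)c1ccc(-c2csc(N3N=C(c4ccc(N5CCCCC5)cc4)CC3c3ccc(Cl)cc3)n2)cc1` likewise gives the limit > 100000 nM in this assay. The step that the two limits leave unreadable from compound 1 to compound 2, methylsulfonyl in place of nitro on an aromatic carbon, therefore has no readable size, since (the limit of > 100000 nM in this assay, at which 2 of the 2 values shown sit). Compound 3 `Clc1ccc(C2CC(c3ccc(N4CCCCC4)cc3)=NN2c2nc(-c3ccc4ccccc4c3)cs2)cc1` differs from compound 1 by naphthalen-2-yl in place of 4-nitrophenyl on an aromatic carbon. Among the compounds with values here, no measured step bears on this change, so no direction can be read from the data. Compound 3 is expected to give 100000 nM, within 20000 nM to 300000 nM, in this assay. The expected step of a number no higher from compound 1 to compound 3 (the limit leaves the size open) is an estimate only.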

Compound 3, half-maximal inhibitory concentration: > 100000 nM
Compound 3 was reported as a limit; the forecaster's own chance of this, stated with the estimate: 65%; the middle value sits exactly at the limit.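

No step from compound 1 or compound 2 to compound 3 can be read, as compound 3 also gives only a limit: the limit of > 100000 nM in this assay, at which 3 of the 3 values shown sit.

From the compounds shown here alone, whether 4-nitrophenyl, 4-(methylsulfonyl)phenyl and naphthalen-2-yl differ at all in this assay stays open.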